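Swapping an Ethenyl Arm for an Arylamino Arm on the Carbonyl

A few compounds are considered here, and "the series" means these few. Any claim that something is new, unique, unknown or untested is made for them only; others in the source may bear on it.

Compound 1 `COc1cc(NC(C)CCCNC(=O)NCc2ccncc2)c2ncccc2c1`: "not determined" (no result reported)
Compound 2 `COc1ccc(/C(=N/NC(=O)NCCCC(C)Nc2cc(OC)cc3cccnc23)c2ccccc2)cc1`: > 195000 nM, a limit of the assay
Compound 3 `COc1cc(NC(C)CCCNC(=O)NNC(=O)/C=C/c2ccccc2F)c2ncccc2c1`: 25100 nM

The three measured compounds share one core and differ in the arm that hangs from the urea or hydrazide end. In an ADME assay on L6 cells (Rattus norvegicus) for cytotoxicity, read by resazurin assay, with a stated time of 70 h (a lower number here means a stronger inhibitor, a higher number a weaker inhibitor), compound 1 has "not determined" (no result reported). For compound 2 the assay gives only a limit, > 195000 nM, and not a number. Going by the values given here, compound 3 is the only compound with a number, giving 25100 nM in this assay, so there is no measured step from one compound to another on which a trend could rest.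

Compound 4 `COc1cc(NC(C)CCCNC(=O)NNC(=O)Nc2ccc(C(F)(F)F)cc2)c2ncccc2c1` has not been tested yet. It differs from compound 3 in one place: (4-(trifluoromethyl)phenyl)amino in place of 2-(2-fluorophenyl)ethenyl on a carbonyl carbon. The carbonyl carbon keeps its amide-type nitrogen neighbour, so the change lies entirely in the arm attached to it.

Among the compounds with values here, with no measured step to lean on, compound 4 is expected to stay close to compound 3, with the step of a 1.6-fold higher number from compound 3 to compound 4 (0.20 log units; within the scatter) expected to fall within or only slightly beyond the usual scatter toward a weaker inhibitor. Compound 4 is therefore estimated at 40000 nM in this assay, with a range from 12000 nM to 150000 nM.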

Compound 4, half-maximal inhibitory concentration: 14900 nM
For compound 4 the middle estimate is 2.7-fold (0.43 log units) above the measured one; measured number inside the range.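

In this assay, the arm on the carbonyl carbon can now be judged by a measured step, a 1.7-fold lower number from compound 3 to compound 4 (0.23 log units; within the scatter), so the two compounds cannot be told apart in this read-out. This exchange is not a small one: an arm with a double bond outside the aromatic ring and no hydrogen-bond donor leaves, and an arm with more heavy atoms, a nitrogen and one hydrogen-bond donor enters, yet the cell read-out does not separate them. Nothing measured here offers a reason for this outcome.

The exchange alters the link to the aromatic ring and the group carried on that ring at the same time, so the compounds shown cannot separate the share of each, and an arm such as (2-fluorophenyl)amino, which would keep the fluorine while taking on the nitrogen link, is needed to pull the two apart. From the compounds shown here alone, it also stays open whether a quite different arm on the same carbonyl carbon, such as one ending in a carboxylic acid or an aliphatic amine, would remain within the scatter of these two compounds.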